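This account rests on a few compounds, and the source may have more. Where it says the series, first, only, none or still open, it means among the compounds named here.

Compound 3 `COc1cc(OC)c(-c2coc3cc(OCc4ccccc4)ccc3c2=O)cc1OC` gives 1320 nM in a functional assay on HepG2 cells (Homo sapiens) for antiproliferative activity, read by MTT assay, with a stated time of 24 h (a higher number here means a weaker inhibitor, a lower number a stronger inhibitor), the lowest of the three numbers measured. Compound 1 `C=CCOc1ccc2c(=O)c(-c3cc(OC)c(OC)cc3OC)coc2c1` gives 3450 nM in this assay, and compound 2 `C#CCOc1ccc2c(=O)c(-c3cc(OC)c(OC)cc3OC)coc2c1` gives 4950 nM. The step of a 2.6-fold lower number from compound 1 to compound 3 (0.42 log units; beyond the scatter) and the step of a 3.8-fold lower number from compound 2 to compound 3 (0.57 log units; beyond the scatter) both lie beyond the scatter, so compound 3 is the strongest inhibitor of the measured set, while the step of a 1.4-fold higher number from compound 1 to compound 2 (0.16 log units; within the scatter) stays within it.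

Compound 4 `COc1ccc2c(=O)c(-c3cc(OC)c(OC)cc3OC)coc2c1` has not yet been measured. It differs from compound 3 in one place: hydrogen in place of phenyl on a saturated chain carbon bound to an oxygen on an aromatic ring. Among the compounds with values here, no measured pair shows this exact exchange. What the data do show is that putting phenyl in place of vinyl or ethynyl on this chain carbon lowered the number by a modest amount. Compound 4 now removes the phenyl altogether, leaving only hydrogen, which runs opposite to the two measured steps that gave compound 3 its position. A rise in the number beyond the scatter is therefore expected for compound 4, probably at least as large as the step of a 2.6-fold lower number from compound 1 to compound 3 (0.42 log units; beyond the scatter) in reverse. Compound 4 is expected to give 5500 nM in this assay, within a range of 2000 nM to 15000 nM, an expected step of a 4.2-fold higher number from compound 3 to compound 4 (0.62 log units; beyond the scatter).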

Compound 4, half-maximal inhibitory concentration: 2040 nM
Estimate against measurement, compound 4: 2.7-fold (0.43 log units) above; the measured number falls inside the stated range.
By their numbers in this assay, from the lowest: compounds 3, 4, 1 and 2 (each within the scatter of the next, the first and the last beyond it).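

In this assay, cutting the benzyloxy group of compound 3 back to the methoxy group of compound 4 gives a 1.5-fold higher number from compound 3 to compound 4 (0.19 log units; within the scatter), so the phenyl that seemed to set compound 3 apart from compounds 1 and 2 is not needed to keep the number within the scatter of compound 3. Bare hydrogen on this chain carbon gives a 2.4-fold lower number from compound 2 to compound 4 (0.38 log units; beyond the scatter) against ethynyl but only a 1.7-fold lower number from compound 1 to compound 4 (0.23 log units; within the scatter) against vinyl, which places compound 4 within the scatter of both compound 3 and compound 1, even though those two lie beyond the scatter of each other; the ethynyl of compound 2 is the one exchange with hydrogen that shows a change, and it is a modest one. Nothing measured here gives a reason for this pattern.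

The compounds shown leave open what an amine or a carboxylic acid carried on this chain carbon would do to the number. They also leave open whether a longer saturated chain, such as butyl, or a phenyl bearing a chlorine would move it clearly away from that of compound 4.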